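A few compounds are considered here, and "the series" means these few. Any claim that something is new, unique, unknown or untested is made for them only; others in the source may bear on it.

Compound 1 `Cn1cc(/C=C/C(=O)c2ccccc2)cc1/C=C/C(=O)NO`: 260 nM
Compound 2 `Cn1cc(/C=C/C(=O)c2ccccc2Cl)cc1/C=C/C(=O)NO`: 1600 nM
Compound 3 `COc1cccc(C(=O)/C=C/c2cc(/C=C/C(=O)NO)n(C)c2)c1`: 600 nM

These numbers come from an assay on isolated protein for inhibition of histone deacetylase HD1B (Zea mays); a higher number here means a weaker inhibitor, a lower number a stronger inhibitor. Compound 3 stands second highest of the three: compound 1 gives 260 nM beneath it, and compound 2 gives 1600 nM above it. Compound 4 `Cn1cc(/C=C/C(=O)c2ccsc2)cc1/C=C/C(=O)NO` is derived from compound 3 by thiophen-3-yl in place of 3-methoxyphenyl on a carbonyl carbon. Within the data shown here, two measured steps touch the same aryl group on that carbonyl carbon: a 2.3-fold higher number from compound 1 to compound 3 (0.36 log units; beyond the scatter) and a 2.7-fold lower number from compound 2 to compound 3 (0.43 log units; beyond the scatter), both modest. Among the measured compounds shown here, neither exchanges the ring itself, so the present step is only loosely anchored; the earlier steps suggest a modest change in this assay in either direction, or none beyond the scatter. Compound 4 is therefore expected to give about 400 nM, within 130 nM to 1200 nM. The expected step is a 1.5-fold lower number from compound 3 to compound 4 (0.18 log units; within the scatter).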

Compound 4, half-maximal inhibitory concentration: 22600 nM
Estimate against measurement, compound 4: 57-fold (1.75 log units) below; measured number outside the range, above it.
By their numbers in this assay, from the lowest: compound 1; then compound 3; then compound 2; then compound 4.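

In this assay thiophen-3-yl on the carbonyl carbon gives a 38-fold higher number from compound 3 to compound 4 (1.58 log units; beyond the scatter) and a 14-fold higher number from compound 2 to compound 4 (1.15 log units; beyond the scatter) and an 87-fold higher number from compound 1 to compound 4 (1.94 log units; beyond the scatter) as its three steps. Exchanging the ring at this place thus moves the number much further than chloro or methoxy on the phenyl ring did, each step being large where those were modest. No measurement shown here explains this loss.

The compounds shown leave open whether the loss follows the sulfur, the five-membered ring or the point of attachment. A thiophen-2-yl, furan-3-yl or pyridin-3-yl group on the same carbonyl carbon would separate these.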